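The compounds below may be only part of what the source reports. "The series", "measured", "known", "first", "only" and "open" are said of these compounds alone.

Compound 1 `O=C(Nc1cc(C(F)(F)F)cc(C(F)(F)F)c1)C1CCc2ccccc2N1C(=O)c1ccc(Cl)cc1` gives 2570 nM in a functional assay on ACHN cells (Homo sapiens) for cytotoxicity, read by sulforhodamine B assay, with a stated time of 72 h (a higher number here means a weaker inhibitor of growth, a lower number a stronger inhibitor of growth), the lowest of the two numbers among the measured compounds. Compound 2 `CCCCCCCCC(=O)N1c2ccccc2CCC1C(=O)Nc1ccccc1O`, which carries a long alkyl chain on the ring carbonyl and a hydroxyphenyl amide, gives 65000 nM in this assay, a value that sits well beyond the scatter of compound 1. Compound 3 `CCCC(=O)N1c2ccccc2CCC1C(=O)Nc1ccccc1C(F)(F)F`, with a butanoyl group on the ring nitrogen, gives > 70000 nM in this assay. That value is a limit of the assay and not a number, (the limit of > 70000 nM in this assay, at which 1 of the 3 values shown sits), so no number is known for compound 3. None of these three compounds differs from another in a single place, so no direct step can be read between them.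

Compound 4 `CCC(=O)N1c2ccccc2CCC1C(=O)Nc1cc(C(F)(F)F)cc(C(F)(F)F)c1` keeps the bis(trifluoromethyl)phenyl amide of compound 1 and differs from it only at the ring carbonyl: ethyl in place of 4-chlorophenyl on a carbonyl carbon. Both other measured compounds carry an alkyl group in that same position, and both are weak. Compound 4 is therefore expected to lose potency relative to compound 1, with a step of a 5.8-fold higher number from compound 1 to compound 4 (0.77 log units; beyond the scatter) in this assay, because compound 2 gives 65000 nM. For compound 4 the estimate in this assay is 15000 nM, within a range from 3000 nM to 70000 nM.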

Compound 4, concentration for 50% growth inhibition: 7720 nM
The estimate for compound 4 lay 1.9-fold (0.29 log units) above the measured number, and the stated range covers the measured number.
By their numbers in this assay, from the lowest: compound 1; then compound 4; then compound 2. At a limit, above all of these: compound 3.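

For the compounds shown here, with the bis(trifluoromethyl)phenyl amide held constant, this pair gives the first direct reading of the group on a carbonyl carbon whose other neighbour is the amide-type nitrogen in a ring: in this assay, ethyl in place of 4-chlorophenyl gives a 3.0-fold higher number from compound 1 to compound 4 (0.48 log units; beyond the scatter). The step is beyond the scatter but modest, and compound 4 still gives a number, 7720 nM, so growth inhibition in this assay does not depend entirely on the 4-chlorophenyl group and survives its replacement by a much smaller alkyl group. Nothing shown here bears on why the number rises with this change.

Going by these compounds, it remains open whether the step follows the chlorine or the aromatic ring itself, a question that a plain phenyl group at this place would address. On these data alone, how a longer chain such as hexyl, a cyclohexyl ring or a carboxylic acid at the same place would behave alongside this amide also remains open.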